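Two Isoxazole Amides and Esters Compared for Cytotoxicity

A few compounds are considered here, and "the series" means these few. Any claim that something is new, unique, unknown or untested is made for them only; others in the source may bear on it.

Compound 1 `CCOC(=O)c1cc(CCCOc2ccc(-c3noc(C(F)(F)F)n3)cc2C(F)(F)F)on1` and compound 2 `CN(C)C(=O)c1cc(CCCOc2ccc(-c3noc(C(F)(F)F)n3)cc2C(F)(F)F)on1` share the same core and differ only at the group attached to the carbonyl carbon. In an ADME assay on HeLa cells (Homo sapiens) for cytotoxicity, read by crystal violet staining, with a stated time of 72 h (on this read-out lower numbers stand for higher toxicity in this test and higher numbers for lower toxicity in this test), compound 1 gives 28400 nM, while compound 2 gives 19200 nM. The change that separates them is dimethylamino in place of ethoxy on a carbonyl carbon and it produced a 1.5-fold lower number from compound 1 to compound 2 (0.17 log units; within the scatter), so in this pairing the two groups are not distinguished by the test.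

Compound 3 `CCOC(=O)c1cc(CCCOc2ccc(-c3noc(C(F)(F)F)n3)cn2)on1` carries a different core; how its core differs from that of compound 1 is not broken down here. In this assay compound 3 reaches only the limit of > 100000 nM, which is a limit of the assay and not a number, in line with the limit of > 100000 nM in this assay, at which 1 of the 3 values shown sits.

Compound 4 `CN(C)C(=O)c1cc(CCCOc2ccc(-c3noc(C(F)(F)F)n3)cn2)on1` stands to compound 3 as compound 2 stands to compound 1: the change is dimethylamino in place of ethoxy on a carbonyl carbon, the same change at the same kind of place. Compound 4 has not yet been measured in this assay. Since compound 3 gave only a limit of > 100000 nM, and since the same change gave a 1.5-fold lower number from compound 1 to compound 2 (0.17 log units; within the scatter) on the other core, compound 4 is expected to sit near 130000 nM, most likely again reported as a limit. The step from compound 3 to compound 4 is estimated as a step that the limit leaves unreadable from compound 3 to compound 4. The expected range for compound 4 runs from 50000 nM to 350000 nM.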

Compound 4, half-maximal cytotoxic concentration: 48800 nM
For compound 4 the middle estimate is 2.7-fold (0.43 log units) above the measured one; the measured number lies below the stated range.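

Carried to the core of compound 3, dimethylamino in place of ethoxy on a carbonyl carbon gives in this assay an at least 2.0-fold lower number from compound 3 to compound 4 (0.31 log units; beyond the scatter), a step that lies beyond the scatter, whereas the same change on the core of compound 1 stays within it. As far as these compounds go, compound 3 stands at > 100000 nM, which is a limit of the assay and not a number, so the step gives only a minimum and its true size remains unknown. The result thus shows that the change can be read on both cores, with a lower number on the core of compound 3, but it does not show whether the change has the same size on the two cores: the same change on two cores in this assay, a 1.5-fold lower number (0.17 log units; within the scatter) from compound 1 to compound 2 and an at least 2.0-fold lower number (0.31 log units; beyond the scatter) from compound 3 to compound 4; the limit leaves it open whether they differ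

The compounds shown leave open how other groups on the same carbonyl carbon, such as amino, methylamino or the hydroxyl of a carboxylic acid, would read in this assay. They also leave open whether a longer chain on the ester oxygen, such as propoxy or butoxy in place of ethoxy, would give a different result on either core.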